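This account rests on a few compounds, and the source may have more. Where it says the series, first, only, none or still open, it means among the compounds named here.

Measured in an ADME assay on Huh-7 cells (Homo sapiens) for cytotoxicity, read by MTT assay; a higher number here means that more compound is tolerated, a lower number that less compound is tolerated:
Compound 1 `CC(C)(C)C(=O)N(CCCCCCN1C[C@H](O)[C@@H](O)[C@H](O)[C@H]1CO)C1CCCCC1`: 500000 nM
Compound 2 `O=C(c1ccccc1)N(CCCCCCN1C[C@H](O)[C@@H](O)[C@H](O)[C@H]1CO)C1CCCCC1`: > 500000 nM
Compound 3 `O=S(=O)(c1ccccc1)N(CCCCCCN1C[C@H](O)[C@@H](O)[C@H](O)[C@H]1CO)C1CCCCC1`: 280000 nM

Compound 2 has no exact number in this assay, only a limit: the limit of > 500000 nM in this assay, at which 1 of the 3 values shown sits. The change to compound 4 `CCCNC(=O)N(CCCCCCN1C[C@H](O)[C@@H](O)[C@H](O)[C@H]1CO)C1CCCCC1` places propylamino in place of phenyl on a carbonyl carbon, turning benzoyl into propylcarbamoyl: propylamino in place of phenyl on a carbonyl carbon.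

On these data alone, the closest measured change at this place is a number no lower from compound 1 to compound 2 (the limit leaves the size open), and its size stays open. The swaps of the whole group on the amine nitrogen give a 1.8-fold lower number from compound 1 to compound 3 (0.25 log units; within the scatter) and an at least 1.7-fold lower number from compound 2 to compound 3 (0.25 log units; that floor lies within the scatter). The second of these is also only a floor. None of the three is shown to go beyond the scatter, and no measured compound carries propylamino. The expectation is therefore an at least 1.2-fold lower number from compound 2 to compound 4 (0.09 log units; that floor lies within the scatter), with no shift beyond the scatter in either direction. Compound 4 is estimated at 400000 nM, with an expected range from 180000 nM to 800000 nM.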

Compound 4, half-maximal cytotoxic concentration: > 500000 nM
Compound 4: a limit, no number; the forecaster's own chance of this, stated with the estimate: 40%; middle value at least 1.2-fold (0.09 log units) from the limit.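

In this assay compound 4 gives > 500000 nM, which is a limit of the assay and not a number. Compound 4 thus shows that the aromatic ring of the benzoyl group in compound 2 is not needed to reach this limit, since propylcarbamoyl carries no ring, and replacing phenylsulfonyl with propylcarbamoyl on the amine nitrogen gives an at least 1.7-fold higher number from compound 3 to compound 4 (0.25 log units; that floor lies within the scatter). Propylamino in place of tert-butyl on the carbonyl carbon gives a number no lower from compound 1 to compound 4 (the limit leaves the size open). The step to compound 4 from compound 2 cannot be read, because compound 4 ends at the limit that also holds compound 2: the limit of > 500000 nM in this assay, at which 2 of the 4 values shown sit.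

On these data alone, how far compound 2 and compound 4 lie past this limit remains unknown. Also open, as far as these compounds go, is whether a longer chain such as hexylamino, or dimethylamino, on the same carbonyl carbon would stay at the limit.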